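Para fluoro for methoxy on the styryl ring

The source may hold more compounds than are shown below. What is called first, only, known or untested is meant among the compounds shown, and "the series" means these compounds.

Going by the values given here, compound 3 `COC(=O)/C=C/c1cccc(N(Cc2ccc(/C=C/c3ccc(OC)cc3)cc2)C(=O)C2CCCCC2)c1` gives 208 nM in an assay on isolated protein with Bile acid receptor (Homo sapiens) as the target (a lower number here means that less compound is needed, a higher number that more compound is needed for the effect), the second highest of the three numbers known; compound 1 `COC(=O)/C=C/c1cccc(N(Cc2ccc(/C=C/c3cccc(F)c3)cc2)C(=O)C2CCCCC2)c1` gives 86 nM, and compound 2 `COC(=O)/C=C/c1cccc(N(Cc2ccc(/C=C/c3ccc(F)cc3)cc2)C(=O)NC(C)C)c1` gives 348 nM, a gap from compound 3 within the scatter. Compound 4 `COC(=O)/C=C/c1cccc(N(Cc2ccc(/C=C/c3ccc(F)cc3)cc2)C(=O)C2CCCCC2)c1` carries fluoro in place of methoxy on an aromatic carbon, fluoro in place of methoxy on an aromatic carbon, para to a large group. Among the compounds with values here, the only step that bears on it is a 2.4-fold higher number from compound 1 to compound 3 (0.38 log units; beyond the scatter), where the fluorophenyl member gave the lower number; compound 2 shows a fluorophenyl on a different amide and sits near compound 3. A modest decrease is therefore expected, a 1.9-fold lower number from compound 3 to compound 4 (0.28 log units; within the scatter). Compound 4 is estimated at 110 nM, within 50 nM to 250 nM.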

Compound 4, half-maximal effective concentration: 185 nM
Compound 4: the middle estimate sits 1.7-fold (0.23 log units) below what was measured; measured number inside the range.
By their numbers in this assay, from the lowest: compound 1; then compounds 4, 3 and 2 (each within the scatter of the next).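

In this assay, fluoro in place of methoxy on an aromatic carbon, para to a large group, gives a 1.1-fold lower number from compound 3 to compound 4 (0.05 log units; within the scatter), so the two groups are not separated on the cyclohexyl amide. With 4-fluorophenyl fixed, cyclohexyl in place of isopropylamino gives a 1.9-fold lower number from compound 2 to compound 4 (0.27 log units; within the scatter), also unresolved, whereas the ring position of fluoro does register, with a 2.2-fold higher number from compound 1 to compound 4 (0.33 log units; beyond the scatter) as its step. No supporting data bear on why these groups compare as they do. From the compounds shown here alone, whether an amine or a carboxylic acid at this ring position would separate from fluoro and methoxy remains open, as does whether 3-fluorophenyl keeps its lower number alongside isopropylamino.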